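Moving the methoxy group of compound 1

A few compounds are considered here, and "the series" means these few. Any claim that something is new, unique, unknown or untested is made for them only; others in the source may bear on it.

In a functional assay on T98G cells (Homo sapiens) for inhibition, read by MTT assay, with a stated time of 72 h (on this read-out higher numbers stand for weaker inhibition and lower numbers for stronger inhibition), compound 1 (`COc1ccc(NC(=S)NC2CC(C)(C)Oc3ccc(Br)cc32)cc1`) gives 33000 nM, the higher of the two numerical results. Compound 2 (`CC1(C)CC(NC(=S)Nc2ccc([N+](=O)[O-])cc2)c2cc(Br)ccc2O1`) gives 5000 nM. Compound 3 (`CCNC(=S)NC1CC(C)(C)Oc2ccc(Cl)cc21`) is recorded only as a limit, > 100000 nM.

Compound 4 (`COc1ccccc1NC(=S)NC1CC(C)(C)Oc2ccc(Br)cc21`) has yet to be measured. Its change from compound 1 is 2-methoxyphenyl in place of 4-methoxyphenyl on an amide-type nitrogen, with the same atoms joined differently.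

Among the measured compounds shown here, only one measured step bears on this change: a 6.6-fold lower number from compound 1 to compound 2 (0.82 log units; beyond the scatter). That modest step replaces methoxy with nitro rather than moving the methoxy, so it offers a rough guide to size but no direction for compound 4. A smaller step is therefore expected, probably within the scatter, with neither direction favoured. The expected step is a 1.1-fold lower number from compound 1 to compound 4 (0.04 log units; within the scatter). The estimated value for compound 4 is 30000 nM, with an expected range from 10000 nM to 90000 nM.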

Compound 4, half-maximal inhibitory concentration: 42000 nM
Compound 4: the middle estimate sits 1.4-fold (0.15 log units) below what was measured; the measured number falls inside the stated range.
By their numbers in this assay, from the lowest: compound 2; then compounds 1 and 4 (each within the scatter of the next). At a limit, above all of these: compound 3.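

In this assay, moving the methoxy group gives a 1.3-fold higher number from compound 1 to compound 4 (0.10 log units; within the scatter). Among the compounds shown here, the place of the methoxy group on this aryl ring, attached to an amide-type nitrogen, therefore makes no difference beyond the scatter for this pair, something the earlier compounds could not show. The one step that does go beyond the scatter changes the group itself, as a 6.6-fold lower number from compound 1 to compound 2 (0.82 log units; beyond the scatter), and nothing in the data shown accounts for either outcome.

The compounds shown leave open whether an amine or a carboxylic acid in place of the methoxy group would lower the number as the nitro group does. They also leave open whether a longer chain than the ethyl of compound 3, whose result is only a limit, would give a measurable value.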